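A few compounds are considered here, and "the series" means these few. Any claim that something is new, unique, unknown or untested is made for them only; others in the source may bear on it.

In a functional assay on SW-620 cells (Homo sapiens) for cytotoxicity, read by MTT assay, with a stated time of 48 h (on this read-out higher numbers stand for weaker inhibition and lower numbers for stronger inhibition), compound 1 `CCCCCCCCCCCCCCNC(=O)[C@@H](N)[C@@H](C)O` gives 18700 nM, compound 2 `CCCCCCCCCCCCCCCCCCNC(=O)[C@@H](N)[C@@H](C)O` gives 21400 nM, and compound 3 `CCCCCCCCCCCCCCNC(=O)[C@@H](NS(=O)(=O)c1ccc2ccccc2c1)[C@@H](C)O` gives 9360 nM. Compound 2 thus holds the highest of the three numbers: its nearest neighbour is compound 1, within the scatter, and its furthest is compound 3, beyond it. For the measured compounds named here, the only step that can be read between measured compounds, a 1.1-fold higher number from compound 1 to compound 2 (0.06 log units; within the scatter), alters the chain alone and says nothing about the amine nitrogen. Compound 4 `CCCCCCCCCCCCCCCCCCNC(=O)[C@@H](NC(=O)c1cccs1)[C@@H](C)O` differs from compound 2 by (thiophen-2-yl)carbonyl in place of hydrogen on an amine nitrogen. Going by the values given here, no measured step touches this position directly; the only hint is that compound 3, which also carries a substituent on the amine nitrogen, gives a number lower than that of compound 1 by more than the scatter. On that slender basis a modest downward step is expected, a 2.1-fold lower number from compound 2 to compound 4 (0.33 log units; beyond the scatter), with wide uncertainty. Compound 4 is therefore estimated at 10000 nM in this assay, between 4000 nM and 25000 nM.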

Compound 4, half-maximal inhibitory concentration: 200000 nM
Estimate against measurement, compound 4: 20-fold (1.30 log units) below, outside the stated range (above it).
By their numbers in this assay, from the lowest: compounds 3, 1 and 2 (each within the scatter of the next, the first and the last beyond it); then compound 4.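

In this assay the amine nitrogen proves to be a sensitive position: (thiophen-2-yl)carbonyl in place of hydrogen gives a 9.3-fold higher number from compound 2 to compound 4 (0.97 log units; beyond the scatter) and so moves the number beyond the scatter, whereas the earlier 1.1-fold higher number from compound 1 to compound 2 (0.06 log units; within the scatter) changed the chain alone and stayed within it. A substituent on this nitrogen does not lower the number as a rule, since compound 1 gives 18700 nM and compound 3 gives 9360 nM on the shorter chain, while the change on the longer chain raises it. No available evidence accounts for this rise. On these data alone, whether the opposite directions follow the group or the chain remains open, and (thiophen-2-yl)carbonyl on the chain of compound 1 would separate the two. As far as these compounds go, whether a benzoyl or an acetyl group on this nitrogen would behave like (thiophen-2-yl)carbonyl also remains open.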